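Amino in Place of Chloro: Cytotoxicity Expected for Compound 4

The source may hold more compounds than are shown below. What is called first, only, known or untested is meant among the compounds shown, and "the series" means these compounds.

Three compounds share one core. Compound 1 `CCn1cc(-c2nc3ccccc3[nH]2)c(=O)c2cc(F)c(N3CCNCC3)cc21` gives 4700 nM in a functional assay on A549 cells (Homo sapiens) for cytotoxicity, read by sulforhodamine B assay, with a stated time of 48 h; a higher number here means a weaker inhibitor, a lower number a stronger inhibitor. Compound 2 `CCn1cc(-c2nc3ccc(Cl)cc3[nH]2)c(=O)c2cc(F)c(N3CCNCC3)cc21` gives 500 nM in this assay, the lowest of the three numbers, and compound 3 `CCn1cc(-c2nc3ccc([N+](=O)[O-])cc3o2)c(=O)c2cc(F)c(N3CCNCC3)nc21` gives 7300 nM. Within the data shown here, the only single-point step among them is a 9.4-fold lower number from compound 1 to compound 2 (0.97 log units; beyond the scatter). Compound 4 `CCn1cc(-c2nc3ccc(N)cc3[nH]2)c(=O)c2cc(F)c(N3CCNCC3)cc21` differs from compound 2 by amino in place of chloro on an aromatic carbon. Among the measured compounds shown here, no measured pair exchanges chloro for amino, so only the step from compound 1 to compound 2 bears on it: it shows that the chloro went with a lower number, and taking it away points toward a higher one, while the entering amino is untested here. A step of middling size back toward compound 1 is therefore expected, a 4.0-fold higher number from compound 2 to compound 4 (0.60 log units; beyond the scatter). Compound 4 is estimated at 2000 nM, between 600 nM and 7000 nM.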

Compound 4, half-maximal inhibitory concentration: > 10000 nM
Compound 4 ended at the assay's limit; the forecaster's own chance of this, stated with the estimate: 5%; middle value at least 5.0-fold (0.69 log units) from the limit.
By their numbers in this assay, from the lowest: compound 2; then compounds 1 and 3 (each within the scatter of the next). At a limit, above all of these: compound 4.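

Compound 4 stands at a limit of this assay, not at a number: the limit of > 10000 nM in this assay, at which 1 of the 4 values shown sits. Amino in place of chloro is a large change, an at least 20-fold higher number from compound 2 to compound 4 (1.30 log units; beyond the scatter), so this position responds to more than the loss of chloro. Amino in place of hydrogen also gives a change, an at least 2.1-fold higher number from compound 1 to compound 4 (0.32 log units; beyond the scatter), in the opposite direction to chloro, so the two groups on this one aromatic carbon move the number opposite ways. Still open, on these data alone, is where fluoro, methoxy or a carboxylic acid on this carbon would fall, and how far past the limit compound 4 actually lies.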